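Swapping a Thiophene Substituent: Predicting a Fourth Pyridine Analogue

This account rests on a few compounds, and the source may have more. Where it says the series, first, only, none or still open, it means among the compounds named here.

The measured compounds and their values:
compound 1, `Cc1ccsc1-c1cc(-c2ccoc2)cc(-c2ccc(Cl)cc2)n1`: 20300 nM
compound 2, `Clc1ccc(-c2cc(-c3ccoc3)cc(-c3ccc(Cl)s3)n2)cc1`: 2600 nM
compound 3, `Cc1ccsc1-c1cc(-c2ccc(Cl)o2)cc(-c2ccco2)n1`: 5570 nM

All three were tested in a functional assay on MCF7 cells (Homo sapiens) for cytotoxicity, read by ELISA, with a stated time of 4 days; on this read-out lower numbers stand for stronger inhibition and higher numbers for weaker inhibition. Compound 1 gives the highest number of the three, and compound 2 the lowest. Compound 3 sits between them: its number is higher than that of compound 2 and lower than that of compound 1, and both gaps are beyond the usual scatter.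

Compounds 1 and 2 differ in one place. The change is 5-chlorothiophen-2-yl in place of 3-methylthiophen-2-yl on an aromatic carbon and it brought a 7.8-fold lower number from compound 1 to compound 2 (0.89 log units; beyond the scatter), a modest step.

Compound 4, `Clc1ccc(-c2cc(-c3ccco3)nc(-c3ccc(Cl)s3)c2)o1`, has not yet been measured. It is related to compound 3 by the same kind of change, (5-chlorothiophen-2-yl in place of 3-methylthiophen-2-yl on an aromatic carbon). The surroundings of the place differ, however: in compound 3 the site is meta to a 5-chlorofuran-2-yl group and meta to a furan-2-yl group, whereas in compound 1 it is meta to a 4-chlorophenyl group and meta to a furan-3-yl group. The difference between the core of compound 3 and the core of compound 1 is not broken down here.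

Because the change from compound 1 to compound 2 gave a 7.8-fold lower number from compound 1 to compound 2 (0.89 log units; beyond the scatter), the same kind of change in compound 4 is expected to lower the number too, though with one precedent only, a somewhat smaller step is estimated: a 5.1-fold lower number from compound 3 to compound 4 (0.70 log units; beyond the scatter). On that basis compound 4 is expected to give about 1100 nM in this assay, likely between 350 nM and 3500 nM.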

Compound 4, half-maximal inhibitory concentration: 16900 nM
Beside the measured number, compound 4's estimate is 15-fold (1.19 log units) below it; measured number above the stated range.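

In this assay, putting 5-chlorothiophen-2-yl in place of 3-methylthiophen-2-yl gave a 3.0-fold higher number from compound 3 to compound 4 (0.48 log units; beyond the scatter), which means weaker inhibition on this core, whereas the same swap gave stronger inhibition on the core of compound 1. The change therefore did not carry over from one core to the other in this series, and its direction reversed: the same change on two cores in this assay, a 7.8-fold lower number (0.89 log units; beyond the scatter) from compound 1 to compound 2 and a 3.0-fold higher number (0.48 log units; beyond the scatter) from compound 3 to compound 4, 24-fold (1.37 log units) apart, beyond the scatter of two such steps. This does not show which part of the core decides the outcome, since the core of compound 3 carries 5-chlorofuran-2-yl and furan-2-yl groups, the core of compound 1 carries 4-chlorophenyl and furan-3-yl groups, and two pairs of compounds cannot separate these differences or support a general rule.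

The compounds shown leave open how the swap would behave if only one of those two groups were altered at a time, for example with furan-2-yl replacing furan-3-yl while 4-chlorophenyl stays in place. They also leave open what a different kind of group at the same place, such as an amine or a carboxylic acid, would do to the number on either core.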